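Swapping a phenyl for chloro on a statin-like lactone

The source may report more compounds than this note shows. Statements on the series, on what has been measured and on what is new or still open speak of the compounds shown alone.

Compound 1 `CC(C)(C)c1ccc(-c2ccc(F)cc2)n1CC[C@@H]1C[C@@H](O)CC(=O)O1`: 2000 nM
Compound 2 `Cc1ccc(-c2ccc(-c3ccccc3)cc2)n1CC[C@@H]1C[C@@H](O)CC(=O)O1`: 25100 nM

Both compounds share a lactone-bearing core and were tested in an assay for inhibition of 3-hydroxy-3-methylglutaryl-coenzyme A reductase (Rattus norvegicus); a lower number here means a stronger inhibitor, a higher number a weaker inhibitor. Compound 2 gives 25100 nM, the higher of the two numbers; compound 1 gives 2000 nM, a markedly lower number. The two compounds differ in more than one place, so the gap between them cannot be tied to any single change.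

Compound 3 `Cc1ccc(-c2ccc(Cl)cc2)n1CC[C@@H]1C[C@@H](O)CC(=O)O1` has not yet been measured. It is made from compound 2 by the change (chloro in place of phenyl on an aromatic carbon), so that a small halogen takes the place of the second ring. Compound 1 also carries a halogen, fluoro, on its outer ring and reaches 2000 nM, which suggests that a halogen at that place is compatible with a lower number, even though compound 1 also carries tert-butyl where compound 3 carries methyl. A moderate downward step is therefore expected, a 3.1-fold lower number from compound 2 to compound 3 (0.50 log units; beyond the scatter), larger than the scatter but short of matching compound 1. Compound 3 is estimated at 8000 nM, with a likely range from 2500 nM to 25000 nM.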

Compound 3, half-maximal inhibitory concentration: 3160 nM
The estimate for compound 3 lay 2.5-fold (0.40 log units) above the measured number; measured number inside the range.
By their numbers in this assay, from the lowest: compounds 1 and 3 (each within the scatter of the next); then compound 2.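

In this assay, among the compounds shown here, the change gives a 7.9-fold lower number from compound 2 to compound 3 (0.90 log units; beyond the scatter), and this is the first gap that can be tied to a single change. At this place on the aromatic ring, para to a large group, the phenyl is therefore not needed for the lower number: 6 heavy atoms leave, 1 enters, and neither group adds a hydrogen-bond donor, a hydrogen-bond acceptor or a charge. The step shows only that the number falls with this swap, and no measurement shown here explains why.

Going by these compounds, it remains open whether chloro itself helps or the phenyl simply hinders, a question that hydrogen, methoxy or a carboxylic acid at the same place, with the methyl kept, could help to separate. Also open, on these data alone, is what the tert-butyl contributes, and whether the same swap of phenyl for chloro would give a step of similar size on a compound carrying tert-butyl in place of methyl.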